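Swapping the group on the carbonyl carbon of compound 3

The source may hold more compounds than are shown below. What is called first, only, known or untested is meant among the compounds shown, and "the series" means these compounds.

In a functional assay on MCF7 cells (Homo sapiens) for antiproliferative activity, read by MTT assay, with a stated time of 48 h (on this read-out higher numbers stand for weaker inhibition and lower numbers for stronger inhibition), compound 1 `C#CCCOC(=O)c1ccc(C(CC)(CC)c2ccc(OCCC(O)(CC)CC)c(C)c2)n1CC` gives > 50000 nM as a limit of the assay. Compound 2 `CCn1c(C(=O)Nc2ccc(OC(F)(F)F)cc2)ccc1C(CC)(CC)c1ccc(OCCC(O)(CC)CC)c(C)c1` gives > 50000 nM as a limit too. Compound 3 `CCn1c(C(=O)Nc2cccc(C(F)(F)F)c2)ccc1C(CC)(CC)c1ccc(OCCC(O)(CC)CC)c(C)c1` also gives > 50000 nM as a limit, and so shares the limit of > 50000 nM in this assay, at which 3 of the 3 values shown sit, with the others. Compound 4 `CCn1c(C(=O)N(C)CC(=O)O)ccc1C(CC)(CC)c1ccc(OCCC(O)(CC)CC)c(C)c1` has (carboxymethyl)(methyl)amino in place of (3-(trifluoromethyl)phenyl)amino on a carbonyl carbon, and the count runs (carboxymethyl)(methyl)amino in place of (3-(trifluoromethyl)phenyl)amino on a carbonyl carbon in full. Among the compounds with values here, the steps that bear on this are a step that the two limits leave unreadable from compound 1 to compound 3 and a step that the two limits leave unreadable from compound 2 to compound 3 and also a step that the two limits leave unreadable from compound 1 to compound 2 in the same series. None gives a size to carry over, so no change beyond the scatter is expected, and the expected step is a step that the limit leaves unreadable from compound 3 to compound 4 for now. For compound 4 the estimate is 60000 nM with an expected range of 20000 nM to 150000 nM in this assay.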

Compound 4, half-maximal inhibitory concentration: 79 nM
For compound 4 the middle estimate is 760-fold (2.88 log units) above the measured one; measured number below the stated range.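

In this assay, (carboxymethyl)(methyl)amino on the carbonyl carbon gives an at least 630-fold lower number from compound 3 to compound 4 (2.80 log units; beyond the scatter), and the same swap gives an at least 630-fold lower number from compound 2 to compound 4 (2.80 log units; beyond the scatter) and an at least 630-fold lower number from compound 1 to compound 4 (2.80 log units; beyond the scatter). Within the data shown here, this shows that the group at this position can separate a readable potency from none, which the earlier compounds could not show, since the steps among them cannot be read. Compound 1, compound 2 and compound 3 all stay at one limit of the assay: the limit of > 50000 nM in this assay, at which 3 of the 4 values shown sit.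

Which part of the entering group carries the gain stays open. A methyl ester in place of the carboxylic acid, or a longer chain bearing that acid, would help to settle this.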